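Side-chain change from compound 3 to compound 4

This account rests on a few compounds, and the source may have more. Where it says the series, first, only, none or still open, it means among the compounds named here.

Values so far in an ADME assay on the whole organism (strain FVB) for pharmacokinetics, with Mus musculus as the target, read by LC-MS, at a dose of 30 mg/kg by the oral route (on this read-out lower numbers stand for lower exposure and higher numbers for higher exposure at the dose given), for the series
- compound 1 `CC(C)(N)CCOc1ccc([C@H]2CC[C@]3(CC2)OOC2(O3)C3CC4CC(C3)CC2C4)cc1` gives 12300 ng.h/mL
- compound 2 `c1cc([C@H]2CC[C@]3(CC2)OOC2(O3)C3CC4CC(C3)CC2C4)ccc1OCC1CCNCC1` gives 4040 ng.h/mL
- compound 3 `N[C@H]1CC[C@@H](Oc2ccc([C@H]3CC[C@]4(CC3)OOC3(O4)C4CC5CC(C4)CC3C5)cc2)CC1` gives 13400 ng.h/mL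

Compound 3 stands at 13400 ng.h/mL at the top of the three numbers, level with compound 1 within the scatter and clear of compound 2 beyond it. Compound 4 `O[C@H]1CC[C@H](NCCCOc2ccc([C@H]3CC[C@]4(CC3)OOC3(O4)C4CC5CC(C4)CC3C5)cc2)CC1` carries 3-((4-hydroxycyclohexyl)amino)propyl in place of 4-aminocyclohexyl on an oxygen on an aromatic ring. Going by the values given here, no measured step makes this exact change. The nearest evidence comes from other swaps of this side chain: a 3.3-fold higher number from compound 2 to compound 3 (0.52 log units; beyond the scatter) lies beyond the scatter and is modest, a 1.1-fold higher number from compound 1 to compound 3 (0.04 log units; within the scatter) lies within it and a 3.0-fold lower number from compound 1 to compound 2 (0.48 log units; beyond the scatter) again lies beyond it as a modest step. These steps are all small, and compound 3 has no measured number above it beyond the scatter, so a fall is more likely than a rise. The step expected is a 2.2-fold lower number from compound 3 to compound 4 (0.35 log units; beyond the scatter) and it is a modest one downward. Compound 4 is estimated at 6000 ng.h/mL with an expected range from 2000 ng.h/mL to 16000 ng.h/mL as the working estimate.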

Compound 4, area under the concentration-time curve: 6570 ng.h/mL
The estimate for compound 4 lay 1.1-fold (0.04 log units) below the measured number, and the stated range covers the measured number.
By their numbers in this assay, from the lowest: compounds 2, 4, 1 and 3 (each within the scatter of the next, the first and the last beyond it).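

In this assay, 3-((4-hydroxycyclohexyl)amino)propyl on the oxygen on an aromatic ring still gives substantial exposure, with a 2.0-fold lower number from compound 3 to compound 4 (0.31 log units; beyond the scatter) as a modest step beyond the scatter. Against the other two side chains the change does not separate: a 1.6-fold higher number from compound 2 to compound 4 (0.21 log units; within the scatter) and a 1.9-fold lower number from compound 1 to compound 4 (0.27 log units; within the scatter) both stay within the scatter, even though compounds 2 and 3 differ beyond it. No measurement at hand speaks to what lies behind these steps.

The compounds shown do not tell whether the hydroxyl or the longer linking chain carries the step from compound 3, as no pair changes only one of them. Also open, as far as these compounds go, is how exposure would respond to a methoxy group or a carboxylic acid in place of that hydroxyl, or to a butyl chain in place of the propyl.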